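This account rests on a few compounds, and the source may have more. Where it says the series, first, only, none or still open, it means among the compounds named here.

Of the compounds shown here, three have been measured in an assay on isolated protein for inhibition of protein deacetylase HDAC6 (Homo sapiens), with a stated time of 60 min; a lower number here means a stronger inhibitor, a higher number a weaker inhibitor. Compound 1 `CS(=O)(=O)c1ccc(-n2ccc3cnc(Nc4cnn(CCCCCCC(=O)NO)c4)nc32)cc1` gives 5.9 nM. Among the compounds with values here, compound 2 `O=C(CCCCCCn1cc(Nc2ncc3ccn(Cc4ccccc4)c3n2)cn1)NO` gives 12.5 nM, and the only single-point change among the measured compounds, a 2.1-fold higher number from compound 1 to compound 2 (0.33 log units; beyond the scatter), concerns the group on the aromatic nitrogen, not the chain that carries the hydroxamic acid. Compound 3 `O=C(CCCCCn1cc(Nc2ncc3ccn(Cc4ccccc4F)c3n2)cn1)NO` gives 15.3 nM, the highest of the three numbers; its gap to compound 2 lies within the scatter, and only compound 1 sits clearly lower.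

Compound 4 `O=C(CCCCCCn1cc(Nc2ncc3ccn(Cc4ccccc4F)c3n2)cn1)NO` differs from compound 3 in one place: (hydroxycarbamoyl)methyl in place of hydroxycarbamoyl on a saturated chain carbon, five bonds along the chain from an aromatic nitrogen. In plain words, the chain between the ring and the hydroxamic acid is lengthened, while everything else stays the same. Within the data shown here, no measured step follows this kind of change, so the expectation rests on compound 2, which already carries the longer chain and gives 12.5 nM, a number within the scatter of compound 3. The step of a 1.3-fold lower number from compound 3 to compound 4 (0.11 log units; within the scatter) is therefore expected to be small, not beyond the scatter. For compound 4 the estimate in this assay is 12 nM, with a range from 5 nM to 30 nM.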

Compound 4, half-maximal inhibitory concentration: 8.4 nM
For compound 4 the middle estimate is 1.4-fold (0.15 log units) above the measured one, and the stated range covers the measured number.
By their numbers in this assay, from the lowest: compounds 1, 4, 2 and 3 (each within the scatter of the next, the first and the last beyond it).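

In this assay, (hydroxycarbamoyl)methyl in place of hydroxycarbamoyl on a saturated chain carbon, five bonds along the chain from an aromatic nitrogen, gives a 1.8-fold lower number from compound 3 to compound 4 (0.26 log units; within the scatter) with the 2-fluorobenzyl group in place, so this chain change is not resolved from scatter. Fluoro in place of hydrogen on an aromatic carbon, a change new to this set, gives a 1.5-fold lower number from compound 2 to compound 4 (0.17 log units; within the scatter) on the longer chain, while 2-fluorobenzyl in place of 4-(methylsulfonyl)phenyl on an aromatic nitrogen gives a 1.4-fold higher number from compound 1 to compound 4 (0.15 log units; within the scatter) and so, unlike the benzyl group, is not separated from the sulfone-bearing compound. No supporting data are available to explain any of these steps.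

The compounds shown leave open how a longer chain, such as one ending in 5-(hydroxycarbamoyl)pentyl, would read in this assay. They also leave open whether chloro in place of fluoro on the benzyl group would give a step beyond the scatter.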